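The source may hold more compounds than are shown below. What is called first, only, known or untested is meant among the compounds shown, and "the series" means these compounds.

Measured compounds:

- compound 1, `c1ccc2c(-c3cn4ccnc4c(-c4ccc5ncn(C6CCCCC6)c5c4)n3)cccc2c1`: 6.33%
- compound 2, `c1ccc(Cn2cnc3ccc(-c4nc(-c5cccc6ccccc56)cn5ccnc45)cc32)cc1`: 12.4%
- compound 3, `c1cn2cc(-c3ccc4c(c3)ncn4C3CCCCC3)nc(-c3ccc4ncn(C5CCCCC5)c4c3)c2n1`: 25.8%

All three numbers come from a functional assay on 786-0 cells (Homo sapiens) for inhibition, read by sulforhodamine B assay, with a stated time of 48 h, tested at 10 uM; on this read-out higher numbers stand for more inhibition at the one concentration tested (going by the name of the read-out) and lower numbers for less inhibition. In this assay compound 1 gives 6.33% and compound 2 gives 12.4%. The two share a core and differ in one place, (benzyl in place of cyclohexyl on an aromatic nitrogen). The step that this change made is a number 6.1 percentage points higher from compound 1 to compound 2 (within the scatter), so the two values cannot be told apart with confidence.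

Among the compounds with values here, compound 3 is built on a different core; how that core differs from the one in compound 1 is not broken down here. In this assay compound 3 gives 25.8%, the highest of the three numbers, and its distance to both compound 2 and compound 1 lies beyond the usual scatter.

Compound 4, `c1ccc(Cn2cnc3ccc(-c4nc(-c5ccc6c(c5)ncn6C5CCCCC5)cn5ccnc45)cc32)cc1`, has not yet been measured. It is made from compound 3 by the same change that turns compound 1 into compound 2: benzyl in place of cyclohexyl on an aromatic nitrogen. The surroundings of the place are the same in both pairs. The step expected for this change is a number 4.2 percentage points higher from compound 3 to compound 4 (within the scatter), and that expectation rests on the step seen once before, from compound 1 to compound 2, a number 6.1 percentage points higher from compound 1 to compound 2 (within the scatter), which stayed inside the scatter. A small shift is therefore expected, with compound 4 staying near compound 3. For compound 4 the estimated value is 30%, with an expected range from 15% to 45%.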

Compound 4, a percentage reported as inhibition, at one concentration (the size of the read-out at that concentration, not a potency): -19.4%
For compound 4 the middle estimate is 49.4 percentage points above the measured one; the whole stated range lies above it.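

In this assay, putting benzyl in place of cyclohexyl on an aromatic nitrogen gave a number 45.2 percentage points lower from compound 3 to compound 4 (beyond the scatter), so a step seen on one core did not predict the step on the other. The two steps clearly disagree: the same change on two cores in this assay, a number 6.1 percentage points higher (within the scatter) from compound 1 to compound 2 and a number 45.2 percentage points lower (beyond the scatter) from compound 3 to compound 4, 51.3 percentage points apart, beyond the scatter of two such steps. Within the data shown here, this shows that the effect of the change depends on the rest of the molecule, but with only two pairs, each read at a single concentration, it does not show which part of the molecule is responsible, why the steps differ, or which of the two steps a further core would resemble.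

The compounds shown leave open how other groups on that same aromatic nitrogen would behave, for example a longer chain such as n-butyl, or a benzyl carrying an amine or a carboxylic acid. They also leave open what would happen on the core of compound 3 if benzyl replaced the second cyclohexyl as well, and whether such a compound would read closer to compound 3 or to compound 4.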